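The compounds below may be only part of what the source reports. "The series", "measured", "known", "first", "only" and "open" are said of these compounds alone.

Three compounds share one core and differ only in the group on the carbonyl carbon of the ring amide. Compound 1 `CCCS(=O)(=O)N1CCN(c2ccc(OCC3CCN(C(=O)OC(C)C)CC3)cn2)CC1` carries an isopropoxy there and in a functional assay on CHO-K1 cells for agonist activity at Glucose-dependent insulinotropic receptor (Homo sapiens), read by a luciferase reporter, with a stated time of 5 h (a higher number here means that more compound is needed for the effect, a lower number that less compound is needed), compound 1 gives 300 nM. Compound 2 `CCCS(=O)(=O)N1CCN(c2ccc(OCC3CCN(C(=O)CC(C)(C)C)CC3)cn2)CC1` carries a neopentyl, and in this assay compound 2 gives 2800 nM. Compound 3 `CCCS(=O)(=O)N1CCN(c2ccc(OCC3CCN(C(=O)C(F)F)CC3)cn2)CC1` carries a difluoromethyl, and in this assay compound 3 gives 2100 nM. Compound 3 thus sits together with compound 2, as a 1.3-fold lower number from compound 2 to compound 3 (0.12 log units; within the scatter) shows, and far from compound 1, as a 7.0-fold higher number from compound 1 to compound 3 (0.85 log units; beyond the scatter) shows; a 9.3-fold higher number from compound 1 to compound 2 (0.97 log units; beyond the scatter) points the same way.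

Compound 4 `CCCS(=O)(=O)N1CCN(c2ccc(OCC3CCN(C(=O)Nc4ccc(C(C)C)cc4)CC3)cn2)CC1` arises from compound 3 by the change ((4-isopropylphenyl)amino in place of difluoromethyl on a carbonyl carbon). Within the data shown here, no measured step places an amino group on this carbonyl carbon, so the expectation rests on the single observation that the heteroatom-bearing isopropoxy of compound 1 gave the lowest number of the three. On that basis compound 4 is expected to give 600 nM in this assay, with a range from 120 nM to 3000 nM, meaning an estimated step of a 3.5-fold lower number from compound 3 to compound 4 (0.54 log units; beyond the scatter), with wide uncertainty.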

Compound 4, half-maximal effective concentration: 900 nM
Compound 4: middle estimate off by 1.5-fold (0.18 log units), on the low side; the measured number falls inside the stated range.
By their numbers in this assay, from the lowest: compound 1; then compound 4; then compounds 3 and 2 (each within the scatter of the next).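

Replacing difluoromethyl with (4-isopropylphenyl)amino on this carbonyl carbon adds an aromatic ring and a hydrogen-bond donor, and in this assay it gives a 2.3-fold lower number from compound 3 to compound 4 (0.37 log units; beyond the scatter) and, against neopentyl, a 3.1-fold lower number from compound 2 to compound 4 (0.49 log units; beyond the scatter). The position therefore accepts this much larger group with a lower number, and among these four compounds the groups joined through nitrogen or oxygen both give lower numbers than those joined through carbon, with no compound going against this. Isopropoxy nevertheless keeps the lowest number, as a 3.0-fold higher number from compound 1 to compound 4 (0.48 log units; beyond the scatter) shows.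

No evidence here explains these differences. Open questions are whether the phenylamino group without its isopropyl, or a small alkylamino group such as isopropylamino, would match isopropoxy, and what a methyl group in place of the amide hydrogen would do.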